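The compounds below may be only part of what the source reports. "The series", "measured", "known", "first", "only" and "open" are said of these compounds alone.

Compound 1 `COC(=O)c1nc(Br)c2cccnc2c1N[C@H]1CC[C@H](N)CC1`
Compound 2 `COC(=O)CNc1c(C(=O)NCc2ccc(F)cc2)nc(Br)c2cccnc12`
Compound 3 `CNCCCNc1c(C(=O)NCc2ccc(F)cc2)nc(Br)c2cccnc12`

In a functional assay on MDA-MB-435 cells (Homo sapiens) for cytotoxicity, read by MTT assay, with a stated time of 72 h (a higher number here means a weaker inhibitor, a lower number a stronger inhibitor), compound 1 gives only a limit, > 20000 nM; it is an assay limit and not a number (the limit of > 20000 nM in this assay, at which 1 of the 3 values shown sits). In this assay compound 2 gives 10000 nM. In this assay compound 3 gives 11000 nM. Going by the values given here, the single measured step, a 1.1-fold higher number from compound 2 to compound 3 (0.04 log units; within the scatter), alters the chain on the amine nitrogen and stays within the scatter. Compound 4 `N[C@H]1CC[C@H](Nc2c(C(=O)Nc3ccccc3)nc(Br)c3cccnc23)CC1` differs from compound 1 at the carbonyl carbon: anilino in place of methoxy on a carbonyl carbon. Among the compounds with values here, no measured step covers this change, and the two measured numbers are both weak. The step of an at least 1.3-fold lower number from compound 1 to compound 4 (0.12 log units; that floor lies within the scatter) is therefore expected to be small, with a fair chance that only a limit is reported again. Compound 4 is estimated at 15000 nM, range 5000 nM to 40000 nM.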

Compound 4, half-maximal inhibitory concentration: 1000 nM
For compound 4 the middle estimate is 15-fold (1.18 log units) above the measured one; measured number below the stated range.
By their numbers in this assay, from the lowest: compound 4; then compounds 2 and 3 (each within the scatter of the next). At a limit, above all of these: compound 1.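

In this assay, going by these compounds alone, the step of an at least 20-fold lower number from compound 1 to compound 4 (1.30 log units; beyond the scatter) is the first beyond the scatter, whereas the step of a 1.1-fold higher number from compound 2 to compound 3 (0.04 log units; within the scatter), a change in the chain on the amine nitrogen, stays within it. The group on the carbonyl carbon therefore matters in this assay, at least for the methoxy-to-anilino change. The size of that step is only a floor, since the value for compound 1 is an assay limit: the limit of > 20000 nM in this assay, at which 1 of the 4 values shown sits.

From the compounds shown here alone, it remains open whether the aromatic ring or the amide hydrogen accounts for the step. A methylamino or benzylamino group on the same carbonyl carbon would help separate the two.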